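Lengthening a Dimethylamino Side Chain on Two Related Cores

A few compounds are considered here, and "the series" means these few. Any claim that something is new, unique, unknown or untested is made for them only; others in the source may bear on it.

Of the compounds shown here, three have so far been measured in a functional assay on HT-29 cells (Homo sapiens) for cytotoxicity, read by MTT assay, with a stated time of 24 h; on this read-out higher numbers stand for weaker inhibition and lower numbers for stronger inhibition. Compound 1 `Cc1cc(-c2nc3cc(Cl)ccc3o2)ccc1NC(=O)CN1CCN(CCN(C)C)CC1` gives 13200 nM. Compound 3 `CN(C)CCN1CCN(CC(=O)Nc2ccc(-c3nc4cc(F)ccc4o3)cc2)CC1` gives 8190 nM in this assay, and compound 2 `CN(C)CCCN1CCN(CC(=O)Nc2ccc(-c3nc4cc(F)ccc4o3)cc2)CC1` gives 2590 nM. The difference between the core of compound 1 and the core of compound 3 is not broken down here. Compound 3 and compound 2 share a core and differ in a single place: (dimethylamino)methyl in place of dimethylamino on a saturated chain carbon, two bonds along the chain from an amine nitrogen in a ring. That change produced the step of a 3.2-fold lower number from compound 3 to compound 2 (0.50 log units; beyond the scatter). Compound 1 has the highest of the three numbers; its gap to compound 3 is within the scatter, so no order between those two can be read, while its gap to compound 2 lies beyond the scatter.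

Compound 4 `Cc1cc(-c2nc3cc(Cl)ccc3o2)ccc1NC(=O)CN1CCN(CCCN(C)C)CC1` has not yet been measured. It is built from compound 1 by the same change: (dimethylamino)methyl in place of dimethylamino on a saturated chain carbon, two bonds along the chain from an amine nitrogen in a ring. The place of the change is the same in both pairs, so it is the same change carried onto the core of compound 1. Going by the values given here, only one measured instance of the change exists, and a different core may not answer in the same way, so the range is kept wide. The step from compound 1 to compound 4 in this assay is expected to be about a 3.1-fold lower number from compound 1 to compound 4 (0.50 log units; beyond the scatter), close in size to the measured one, because a 3.2-fold lower number from compound 3 to compound 2 (0.50 log units; beyond the scatter). For compound 4 the estimated value is 4200 nM, expected to fall between 1800 nM and 10000 nM.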

Compound 4, half-maximal inhibitory concentration: 9150 nM
The estimate for compound 4 lay 2.2-fold (0.34 log units) below the measured number, and the stated range covers the measured number.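

In this assay, going by these compounds alone, the same change on the core of compound 1 gave a 1.4-fold lower number from compound 1 to compound 4 (0.16 log units; within the scatter) and so, on this core, produced no step that can be told apart from the ordinary spread of repeated measurements. Set side by side, the steps on the two cores cannot be said to differ: the same change on two cores in this assay, a 3.2-fold lower number (0.50 log units; beyond the scatter) from compound 3 to compound 2 and a 1.4-fold lower number (0.16 log units; within the scatter) from compound 1 to compound 4, 2.2-fold (0.34 log units) apart, within the scatter of two such steps. The clear step on the core shared by compound 3 and compound 2 is therefore neither confirmed nor contradicted on the core of compound 1, and these two pairs show neither that the change carries over with the same size nor that the two cores answer to it differently.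

The compounds shown leave open whether a chain longer than 3-(dimethylamino)propyl, or a different amine in place of the dimethylamino end, would give a step beyond the scatter on either core. They also leave open which of the features that separate the two cores, if any, matters for the size of the step, and further pairs on each core would be needed to settle it.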